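Trimethoxyphenyl Replaced by Dichlorophenyl: A Step Awaiting Measurement

The source may hold more compounds than are shown below. What is called first, only, known or untested is meant among the compounds shown, and "the series" means these compounds.

Compound 3 `C=CC(=O)Nc1cccc(S(=O)(=O)N2CCC(NC(=O)c3n[nH]cc3NC(=O)c3c(OC)cc(OC)cc3OC)CC2)c1` was tested in an assay on HEK293 cells for inhibition of cyclin-dependent kinase 14 (Homo sapiens), with a stated time of 4 h; a lower number here means a stronger inhibitor, a higher number a weaker inhibitor. In this assay compound 3 gives > 1000 nM, which is a limit of the assay rather than a number. That places compound 3 at the limit of > 1000 nM in this assay, at which 2 of the 3 values shown sit.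

Compound 4 `C=CC(=O)Nc1cccc(S(=O)(=O)N2CCC(NC(=O)c3n[nH]cc3NC(=O)c3c(Cl)cccc3Cl)CC2)c1` keeps the whole of compound 3 except for one exchange: 2,6-dichlorophenyl in place of 2,4,6-trimethoxyphenyl on a carbonyl carbon. For the measured compounds named here, no measured step covers this exchange. Going by the values given here, the only measured step, an at least 2.0-fold lower number from compound 1 to compound 2 (0.30 log units; that floor lies within the scatter), alters a different part of the molecule and leaves the group on the carbonyl carbon untouched, and it therefore says nothing about what the 2,6-dichlorophenyl group contributes. What the data do show is that compound 1 `CCC(=O)Nc1cccc(CN2CCC(NC(=O)c3n[nH]cc3NC(=O)c3c(Cl)cccc3Cl)CC2)c1` and compound 2 `CN(C)C/C=C/C(=O)Nc1cccc(CN2CCC(NC(=O)c3n[nH]cc3NC(=O)c3c(Cl)cccc3Cl)CC2)c1` both carry the 2,6-dichlorophenyl group on the same carbonyl carbon. In this assay compound 1 gives > 1000 nM, a limit of the assay. In this assay compound 2 gives 500 nM. Neither of these shows the 2,6-dichlorophenyl group carrying a compound far into measurable territory on its own.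

For compound 4 the expected step is therefore an at least 1.2-fold lower number from compound 3 to compound 4 (0.09 log units; that floor lies within the scatter), with no direction beyond the scatter claimed. Compound 4 is estimated at 800 nM, between 200 nM and 3000 nM, and there is a real chance that only a limit is reported.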

Compound 4, half-maximal inhibitory concentration: 1000 nM
The estimate for compound 4 lay 1.3-fold (0.10 log units) below the measured number, within the range that was stated.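

In this assay compound 4 gives 1000 nM. Putting 2,6-dichlorophenyl in place of 2,4,6-trimethoxyphenyl on a carbonyl carbon gives a number no higher from compound 3 to compound 4 (the limit leaves the size open). The size of this exchange cannot be read because the result for compound 3 is a limit and not a number: the limit of > 1000 nM in this assay, at which 2 of the 4 values shown sit. For the compounds shown here, compound 1 and compound 2 both carry the 2,6-dichlorophenyl group and so say nothing about a change at this position, whereas this pair offers the first comparison there, and it shows only that the exchange leaves the number no higher, without showing a gain of any readable size.

The compounds shown leave open how far compound 3 actually lies from compound 4, and so whether the loss of the three methoxy groups and the entry of the two chlorines matter at all in this assay. They also leave open whether a phenyl ring carrying an amine or a carboxylic acid, placed on the same carbonyl carbon, would bring the number clearly beyond the value of compound 4.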